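Naphthalene Sulfonamide Gains an Amino Ester Arm

The source may hold more compounds than are shown below. What is called first, only, known or untested is meant among the compounds shown, and "the series" means these compounds.

Measured so far, in an assay on VSM-A10 cells for antagonist activity at Endothelin-1 receptor (Rattus norvegicus); a higher number here means a weaker inhibitor, a lower number a stronger inhibitor:
compound 1 `Cc1noc(NS(=O)(=O)c2cccc3ccccc23)c1C` gives 20000 nM
compound 2 `Cc1noc(NS(=O)(=O)c2ccc(NC(=O)Nc3ccccc3)cc2)c1C` gives 38000 nM

Compound 1 has the lower of the two numbers, yet its gap to compound 2 lies within the scatter, so no order can be read between them. Compound 3 `CCOC(=O)C(C)Nc1cccc2c(S(=O)(=O)Nc3onc(C)c3C)cccc12` arises from compound 1 by a single change: (1-(ethoxycarbonyl)ethyl)amino in place of hydrogen on an aromatic carbon. For the measured compounds named here, no step between measured compounds is known, so any expectation rests on this structural change alone. A sizable step toward a stronger inhibitor is expected, a 10-fold lower number from compound 1 to compound 3 (1.00 log units; beyond the scatter). Compound 3 is therefore estimated at 2000 nM in this assay, within 300 nM to 12000 nM.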

Compound 3, half-maximal inhibitory concentration: 400 nM
Estimate against measurement, compound 3: 5.0-fold (0.70 log units) above, within the range that was stated.
By their numbers in this assay, from the lowest: compound 3; then compounds 1 and 2 (each within the scatter of the next).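

In this assay, (1-(ethoxycarbonyl)ethyl)amino in place of hydrogen on this aromatic carbon brings a large gain (a 50-fold lower number from compound 1 to compound 3 (1.70 log units; beyond the scatter)). This position of the shared core therefore accepts an added chain, and activity responds strongly to the change, giving the first difference here that lies beyond the scatter. No measurement at hand explains the gain.

The compounds shown leave open which part of the arm matters. A plain amine, the carboxylic acid in place of the ethyl ester, or a longer chain could help separate those parts.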